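A few compounds are considered here, and "the series" means these few. Any claim that something is new, unique, unknown or untested is made for them only; others in the source may bear on it.

Of the compounds shown here, three sharing one core have been tested so far, differing only in the ring attached to an aromatic carbon. Compound 1, `CNC(=O)N1CCCc2ccc(NC(=O)c3ccc(-c4ccccc4)cc3)cc21`, carries a phenyl there and gives 74.3% in a functional assay on MV4-11 cells (Homo sapiens) for antiproliferative activity, with a stated time of 6 days, tested at 6.25 uM; a higher number here means a stronger effect of the compound at the concentration tested, a lower number a weaker effect. Compound 2, `CNC(=O)N1CCCc2ccc(NC(=O)c3ccc(-c4ccn(C)n4)cc3)cc21`, gives 97%, and compound 3, `CNC(=O)N1CCCc2ccc(NC(=O)c3ccc(-c4cccnc4)cc3)cc21`, gives 92.1%. On these numbers compound 3 stands second highest of the three: its gap to compound 2 lies within the scatter, while its gap to compound 1 lies beyond it.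

The next compound, compound 4, is `CNC(=O)N1CCCc2ccc(NC(=O)c3ccc(-c4cnn(C(C)=O)c4)cc3)cc21`. Its change from compound 3 is 1-acetyl-1H-pyrazol-4-yl in place of pyridin-3-yl on an aromatic carbon.

Going by the values given here, two measured steps bear on this. Replacing phenyl with a five-membered ring carrying two nitrogens raised the number a number 22.7 percentage points higher from compound 1 to compound 2 (beyond the scatter), and swapping that ring for pyridin-3-yl moved it only a number 4.9 percentage points lower from compound 2 to compound 3 (within the scatter). Both heteroaromatic rings therefore sit close together at the high end, and the step of a number 17.8 percentage points higher from compound 1 to compound 3 (beyond the scatter) shows how far either lies above phenyl. A third ring of the same kind, now bearing an acetyl group, is expected to land in the same region, so no step beyond the scatter is expected in this assay: an estimated a number 2.1 percentage points lower from compound 3 to compound 4 (within the scatter). Compound 4 is thus estimated at 90%, with a range from 75% to 99%.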

Compound 4, a percentage reported as inhibition, at one concentration (the size of the read-out at that concentration, not a potency): 83.8%
Compound 4: middle estimate off by 6.2 percentage points, on the high side; low and high end bracket the measured number.
By their numbers in this assay, from the lowest: compounds 1, 4, 3 and 2 (each within the scatter of the next, the first and the last beyond it).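

At this position, para to a large group, a heteroaromatic ring in place of phenyl does not always give a clear gain in this assay: the change to 1-acetyl-1H-pyrazol-4-yl gives a number 9.5 percentage points higher from compound 1 to compound 4 (within the scatter). The steps up from compound 1 to compound 2 and to compound 3 differ from this, as both lie beyond the scatter. Going by these compounds alone, two pyrazole rings also separate here for the first time, with a number 13.2 percentage points lower from compound 2 to compound 4 (beyond the scatter) on the change from 1-methyl-1H-pyrazol-3-yl, whereas the comparison with the pyridin-3-yl ring gives a number 8.3 percentage points lower from compound 3 to compound 4 (within the scatter) and shows no real separation. Nothing among the data shown explains why these rings differ.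

The two pyrazole rings differ both in the group on the ring nitrogen and in the point of attachment, so the step from compound 2 cannot be assigned to either difference alone, and 1-methyl-1H-pyrazol-4-yl would stand halfway between them. Also open, from the compounds shown here alone, is how a ring carrying an amine or a carboxylic acid would read at this position, and whether the order seen at one concentration would hold in a full potency measurement.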